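Swapping Chloro for Trifluoromethoxy on the Amide Aryl Ring

This account rests on a few compounds, and the source may have more. Where it says the series, first, only, none or still open, it means among the compounds named here.

Three compounds share one core and differ only in the aryl ring attached to the amide carbonyl. In an assay on HEK293 cells for inhibition of Voltage-dependent N-type calcium channel subunit alpha-1B (Homo sapiens), read by FLIPR and calcium flux (on this read-out lower numbers stand for stronger inhibition and higher numbers for weaker inhibition), compound 1 `CS(=O)(=O)c1ccc(C#N)cc1C(=O)N1CCC(N(C2CC2)S(=O)(=O)c2cccc(C(F)(F)F)c2)CC1` gives 670 nM, compound 2 `CS(=O)(=O)c1ccc(Cl)c(C(=O)N2CCC(N(C3CC3)S(=O)(=O)c3cccc(C(F)(F)F)c3)CC2)c1` gives 340 nM, and compound 3 `CS(=O)(=O)c1ccc(C(=O)N2CCC(N(C3CC3)S(=O)(=O)c3cccc(C(F)(F)F)c3)CC2)c(Cl)c1` gives 290 nM. Going by the values given here, compound 3 has the lowest number of the three, but the step of a 1.2-fold lower number from compound 2 to compound 3 (0.07 log units; within the scatter) lies within the scatter, so only the step of a 2.3-fold lower number from compound 1 to compound 3 (0.36 log units; beyond the scatter) separates it clearly from another compound. Compound 4 `CS(=O)(=O)c1ccc(C(=O)N2CCC(N(C3CC3)S(=O)(=O)c3cccc(C(F)(F)F)c3)CC2)c(OC(F)(F)F)c1` keeps the core of compound 3 and changes one group: trifluoromethoxy in place of chloro on an aromatic carbon. Among the compounds with values here, none of the measured steps touches this chloro group; they exchange or relocate the methylsulfonyl and nitrile groups instead, and even the largest of them, a 2.3-fold lower number from compound 1 to compound 3 (0.36 log units; beyond the scatter), was modest, while a 2.0-fold lower number from compound 1 to compound 2 (0.29 log units; within the scatter) stayed within the scatter. There is therefore no measured basis for a large shift in either direction in this assay, and a step no larger than the scatter is expected, a 1.0-fold higher number from compound 3 to compound 4 (0.01 log units; within the scatter). For compound 4 the estimate in this assay is 300 nM, with a range from 100 nM to 900 nM.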

Compound 4, half-maximal inhibitory concentration: 48 nM
For compound 4 the middle estimate is 6.3-fold (0.80 log units) above the measured one; measured number outside the range, below it.
By their numbers in this assay, from the lowest: compound 4; then compounds 3, 2 and 1 (each within the scatter of the next, the first and the last beyond it).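

In this assay, going by these compounds alone, exchanging chloro for trifluoromethoxy on this aromatic carbon, ortho to a large group, gives a 6.0-fold lower number from compound 3 to compound 4 (0.78 log units; beyond the scatter), a larger step than any among the earlier compounds. Within the data shown here, those earlier steps left this chloro group untouched, so this is the first sign that the group at this position can strongly shift the number, with five heavy atoms entering where one leaves and a hydrogen-bond acceptor gained. No measurement here bears on why this exchange lowers the number. Among these compounds, with only one exchange at this position, the size of the entering group cannot be separated from its other features. From the compounds shown here alone, whether a methoxy or trifluoromethyl group here would behave more like chloro or more like trifluoromethoxy remains open, as does whether the exchange would have the same effect on compound 2.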